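This account rests on a few compounds, and the source may have more. Where it says the series, first, only, none or still open, it means among the compounds named here.

Measured so far in an ADME assay on L6 cells (Rattus norvegicus) for cytotoxicity; a higher number here means a weaker inhibitor, a lower number a stronger inhibitor:
- compound 1 `CCN(CC)CCC(=O)OC1CC2(N3CCCC3)CC(c3ccccc3)C1C(c1ccccc1)C2` gives 19200 nM
- compound 2 `CN(C)C12CC(OC(=O)CN3CCC(O)CC3)C(C(c3ccccc3)C1)C(c1ccccc1)C2` gives 102000 nM

Compound 2 has the higher number of the two, and its gap to compound 1 lies beyond the scatter. Compound 3 `O=C(CN1CCC(O)CC1)OC1CC2(N3CCCC3)CC(c3ccccc3)C1C(c1ccccc1)C2` is not yet measured and differs from compound 2 in one place: pyrrolidin-1-yl in place of dimethylamino on a saturated ring carbon in short, pyrrolidin-1-yl in place of dimethylamino on a saturated ring carbon. For the measured compounds named here, compound 1 also carries pyrrolidin-1-yl, but its ester differs as well, so no measured pair isolates this change. With only compound 1 at 19200 nM as a guide, a modest drop in this assay is expected, near the edge of the scatter. The expected move is a 2.3-fold lower number from compound 2 to compound 3 (0.36 log units; beyond the scatter) in this estimate. Compound 3 is estimated at 45000 nM with an expected range from 18000 nM to 110000 nM for now.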

Compound 3, half-maximal inhibitory concentration: 93400 nM
For compound 3 the middle estimate is 2.1-fold (0.32 log units) below the measured one, and the stated range covers the measured number.
By their numbers in this assay, from the lowest: compound 1; then compounds 3 and 2 (each within the scatter of the next).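

In this assay, pyrrolidin-1-yl in place of dimethylamino on the saturated ring carbon gives a 1.1-fold lower number from compound 2 to compound 3 (0.04 log units; within the scatter), so with the 4-hydroxypiperidin-1-yl side chain present, this position shows no change beyond the scatter for this swap. For the compounds shown here, the other change, 4-hydroxypiperidin-1-yl in place of (diethylamino)methyl on a saturated chain carbon bound to a carbonyl carbon, gives a 4.9-fold higher number from compound 1 to compound 3 (0.69 log units; beyond the scatter), the only one of the two steps beyond the scatter. No available evidence accounts for either step.

From the compounds shown here alone, it remains open whether dimethylamino and pyrrolidin-1-yl also read alike when the side chain carries (diethylamino)methyl. Going by these compounds, the response to a morpholin-4-yl or piperidin-1-yl group on the same ring carbon is also open.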